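Removing the Acetyl from Compound 3: An Expectation

The source may report more compounds than this note shows. Statements on the series, on what has been measured and on what is new or still open speak of the compounds shown alone.

Measured compounds:
Compound 1 `COc1cc2ccc(=O)oc2cc1OCCCOc1no[n+]([O-])c1S(=O)(=O)c1ccccc1` gives 2270 nM in a functional assay on MCF7 cells (Homo sapiens) for inhibition, read by MTT assay, with a stated time of 48 h; a lower number here means a stronger inhibitor, a higher number a weaker inhibitor.
Compound 2 `COc1cc2ccc(=O)oc2cc1OCCCCCOc1c[n+]([O-])on1` gives 3850 nM in this assay.
Compound 3 `COc1cc2cc(NC(C)=O)c(=O)oc2cc1OCCCOc1no[n+]([O-])c1S(=O)(=O)c1ccccc1` gives 2400 nM in this assay.

Among these three numbers compound 3 holds the second highest. Its nearest neighbour is compound 1, with a gap that sits within the scatter, and its furthest is compound 2, whose gap is also within the scatter. The three compounds therefore cannot be told apart on the present numbers.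

Compound 4 `COc1cc2cc(N)c(=O)oc2cc1OCCCOc1no[n+]([O-])c1S(=O)(=O)c1ccccc1` has not yet been measured. It differs from compound 3 by hydrogen in place of acetyl on a nitrogen on an aromatic ring, that is, acetamido becomes amino.

Within the data shown here, the only measured step that touches this position is a 1.1-fold higher number from compound 1 to compound 3 (0.02 log units; within the scatter), where acetamido replaced hydrogen and the number barely moved. Taking the acetyl off again, so that an amino remains, is expected to leave the number where it stands, with no step beyond the scatter in either direction.

Compound 4 is therefore estimated at 2400 nM in this assay, between 1000 nM and 5800 nM, which corresponds to an expected step of no change at the digits printed from compound 3 to compound 4 (within the scatter).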

Compound 4, half-maximal inhibitory concentration: 1910 nM
Compound 4: middle estimate off by 1.3-fold (0.10 log units), on the high side, and the stated range covers the measured number.
By their numbers in this assay, from the lowest: compounds 4, 1, 3 and 2 (each within the scatter of the next).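

In this assay, removing the acetyl gives a 1.3-fold lower number from compound 3 to compound 4 (0.10 log units; within the scatter), and placing amino on the aromatic carbon that carries hydrogen in compound 1 gives a 1.2-fold lower number from compound 1 to compound 4 (0.07 log units; within the scatter). The earlier compounds shown here compared only hydrogen with acetamido at this position; with amino added, compounds 1, 3 and 4 cannot be told apart, so neither the acetyl nor the nitrogen that carries it produces a step beyond the scatter here. No available evidence bears on why these numbers stay together.

Going by these compounds, it remains open whether a group of another kind on this aromatic carbon, such as a carboxylic acid, a dimethylamino group or a longer acyl chain on the nitrogen, would produce a step beyond the scatter in this assay. On these data alone, compound 2 differs from compounds 1, 3 and 4 in more than one place, so it also remains open whether hydrogen, acetamido and amino would stay equally close on the chain and end group that compound 2 carries.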